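This account rests on a few compounds, and the source may have more. Where it says the series, first, only, none or still open, it means among the compounds named here.

Measured in a functional assay on A549 cells (Homo sapiens) for antiproliferative activity, read by MTT assay, with a stated time of 48 h; a higher number here means a weaker inhibitor, a lower number a stronger inhibitor:
Compound 1 `COc1ccccc1-n1cc(COC(=O)/C(C)=C/CC/C(C)=C/CC/C(C)=C/CC[C@@H]2[C@@]3(C)CCC(=O)C(C)(C)[C@H]3CC[C@@]2(C)O)nn1`: > 150000 nM, a limit
Compound 2 `C/C(=C\CC/C(C)=C/CC[C@@H]1[C@@]2(C)CCC(=O)C(C)(C)[C@H]2CC[C@@]1(C)O)CC/C=C(\C)C(=O)OCc1cn(-c2ccc(F)c(Cl)c2)nn1`: > 150000 nM, a limit
Compound 3 `COc1cccc(-n2cc(COC(=O)/C(C)=C/CC/C(C)=C/CC/C(C)=C/CC[C@@H]3[C@@]4(C)CCC(=O)C(C)(C)[C@H]4CC[C@@]3(C)O)nn2)c1`: > 150000 nM, a limit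

Compound 3 yields no number in this assay, since compound 3 gives only > 150000 nM, which is a limit. It has no measured position relative to the other two compounds, and the series as a whole sits together: the limit of > 150000 nM in this assay, at which 3 of the 3 values shown sit.

The next compound is compound 4 `C/C(=C\CC/C(C)=C/CC[C@@H]1[C@@]2(C)CCC(=O)C(C)(C)[C@H]2CC[C@@]1(C)O)CC/C=C(\C)C(=O)OCc1cn(-c2ccc(C)cc2)nn1`, and the change that leads to it is 4-methylphenyl in place of 3-methoxyphenyl on an aromatic nitrogen. In words, this is 4-methylphenyl in place of 3-methoxyphenyl on an aromatic nitrogen, with the rest of the structure the same.

The closest guides are the other exchanges of aryl groups at this nitrogen. Among the measured compounds shown here, the first is a step that the two limits leave unreadable from compound 1 to compound 3. The second is a step that the two limits leave unreadable from compound 2 to compound 3. The third is a step that the two limits leave unreadable from compound 1 to compound 2. None of these has a readable size, so the series gives no measured effect of such an exchange in either direction.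

No readable shift is therefore expected in this assay because of the limit of > 150000 nM in this assay, at which 3 of the 3 values shown sit, and the assay will most likely report compound 4 as a limit again. The expected step is a step that the limit leaves unreadable from compound 3 to compound 4, and this carries no firm direction. For compound 4 the estimate is 170000 nM, with an expected range from 70000 nM to 300000 nM.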

Compound 4, half-maximal inhibitory concentration: > 150000 nM
Compound 4: only a limit was reported (the forecaster's own chance of this, stated with the estimate: 80%); the middle value lies beyond the limit too.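

In this assay compound 4 gives > 150000 nM, which is a limit and not a number. Its steps from compound 1, compound 2 and compound 3 cannot be read, and the series stays together: the limit of > 150000 nM in this assay, at which 4 of the 4 values shown sit.

The compounds shown leave open whether exchanging the aryl group on the aromatic nitrogen shifts this activity at all, and in which direction.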